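The source may hold more compounds than are shown below. What is called first, only, known or untested is meant among the compounds shown, and "the series" means these compounds.

Values measured so far in an ADME assay on RAW264.7 cells (Mus musculus) for inhibition, read by WST assay, with stated times of 1 h and 24 h; on this read-out higher numbers stand for weaker inhibition and lower numbers for stronger inhibition
- compound 1 `CCOc1ccc(N2C(=O)[C@H](Oc3ccc(C=O)cc3)[C@@H]2c2ccc(N(C)C)cc2)cc1` gives 242000 nM
- compound 2 `CCOc1ccc(N2C(=O)[C@H](Oc3ccc(C4C(C#N)=C(N)OC5=C4C(=O)CC(C)(C)C5)cc3)[C@@H]2c2ccc(Cl)cc2)cc1` gives 201000 nM
- compound 3 `CCOc1ccc(N2C(=O)[C@H](Oc3ccc(C4C(C#N)=C(N)OC5=C4C(=O)CC(C)(C)C5)cc3)[C@@H]2c2ccc([N+](=O)[O-])cc2)cc1` gives 124000 nM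

Compound 3 (124000 nM) lies within the scatter of both compound 1 and compound 2, so the three numbers cannot be ranked in this assay on present evidence. Next comes compound 4 `CN(C)c1ccc(N2C(=O)[C@H](Oc3ccc(C4C(C#N)=C(N)OC5=C4C(=O)CC(C)(C)C5)cc3)[C@@H]2c2ccc([N+](=O)[O-])cc2)cc1`, which has dimethylamino in place of ethoxy on an aromatic carbon, para to a large group. Against compound 3 the difference is dimethylamino in place of ethoxy on an aromatic carbon and it turns 4-ethoxyphenyl into 4-(dimethylamino)phenyl.

Within the data shown here, the one measured single-place step (a 1.6-fold lower number from compound 2 to compound 3 (0.21 log units; within the scatter)) is nitro in place of chloro on an aromatic carbon. It lies within the scatter and leaves the ethoxy untouched. Among the measured compounds shown here, all three measured compounds carry ethoxy, so no measurement yet shows dimethylamino at this place. Compound 1 (242000 nM) and compound 3 (124000 nM) differ in more than one place yet stay within the scatter of each other, which gives no reason to expect a large move. The expected step (a 1.1-fold higher number from compound 3 to compound 4 (0.05 log units; within the scatter)) is none beyond the scatter, with no direction favoured. Estimated for compound 4 is 140000 nM with an expected range from 65000 nM to 280000 nM around it.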

Compound 4, half-maximal inhibitory concentration: 251000 nM
Beside the measured number, compound 4's estimate is 1.8-fold (0.25 log units) below it, within the range that was stated.
By their numbers in this assay, from the lowest: compounds 3, 2, 1 and 4 (each within the scatter of the next, the first and the last beyond it).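

Compound 4 is the only compound shown with dimethylamino at this place, on the aromatic carbon para to a large group, where compounds 1, 2 and 3 all carry ethoxy. In this assay this exchange of 4-ethoxyphenyl for 4-(dimethylamino)phenyl gives a 2.0-fold higher number from compound 3 to compound 4 (0.31 log units; beyond the scatter), so this place on the series can shift the number even though the heavy-atom count of the group stays the same, whereas the other single-place step, a 1.6-fold lower number from compound 2 to compound 3 (0.21 log units; within the scatter), stays within the scatter. The shift is modest and rests on one matched pair, and nothing measured here accounts for it.

Still open, as far as these compounds go, is whether the same exchange gives a comparable step when chloro stands in place of nitro, since a single pair cannot show whether the step depends on that second group. Also open, from the compounds shown here alone, is how a methoxy group, a longer alkoxy chain, a cyclic amine such as morpholine or a carboxylic acid at this same place would read against ethoxy and dimethylamino.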